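The source may report more compounds than this note shows. Statements on the series, on what has been measured and on what is new or still open speak of the compounds shown alone.

Working notes on the series.

Compound 3 `CC(=O)c1ccc(NC(=O)C(CC(C)C)N(C(=O)c2ccccc2)S(=O)(=O)c2ccccc2)cc1` gives the highest number of the three measured in a functional assay for inhibition, read by spectrophotometry, with a stated time of 20 min, tested at 4 mg/mL; a lower number here means a weaker effect, a higher number a stronger effect of the compound at the concentration tested: compound 3 gives 46.9%. Compound 2 `CC(=O)c1ccc(NC(=O)CN(C(=O)c2ccccc2)S(=O)(=O)c2ccccc2)cc1` stands nearest, as compound 2 gives 40.9%; compound 1 `CC(=O)c1ccc(NC(=O)C(C(C)C)N(C(=O)c2ccccc2)S(=O)(=O)c2ccc([N+](=O)[O-])cc2)cc1` stands furthest, as compound 1 gives 27.2%. Among the measured compounds shown here, the only single step measured so far, a number 6 percentage points higher from compound 2 to compound 3 (within the scatter), stayed within the scatter.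

Compound 4 `CC(=O)c1ccc(NC(=O)C(C(C)C)N(C(=O)c2ccccc2)S(=O)(=O)c2ccccc2)cc1` differs from compound 3 by isopropyl in place of isobutyl on a saturated chain carbon bound to an amide-type nitrogen and a carbonyl carbon. For the measured compounds named here, the one measured step at this position is small, and compound 1, which also carries isopropyl at this place but differs elsewhere as well, offers no direct step. The step of a number 4.9 percentage points lower from compound 3 to compound 4 (within the scatter) is therefore expected to stay within the scatter. For compound 4 the estimate in this assay is 42%, with a range from 28% to 56%.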

Compound 4, a percentage reported as inhibition, at one concentration (the size of the read-out at that concentration, not a potency): 52.2%
Compound 4: the middle estimate sits 10.2 percentage points below what was measured; the range from low to high includes it.
By their numbers in this assay, from the lowest: compound 1; then compounds 2, 3 and 4 (each within the scatter of the next, the first and the last beyond it).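

In this assay isopropyl in place of isobutyl gives a number 5.3 percentage points higher from compound 3 to compound 4 (within the scatter) and so does not separate these two chains at this position. Isopropyl in place of hydrogen gives a number 11.3 percentage points higher from compound 2 to compound 4 (beyond the scatter) and is the first step here beyond the scatter, while isobutyl in place of hydrogen gave a number 6 percentage points higher from compound 2 to compound 3 (within the scatter) and stayed within it. Hydrogen in place of nitro on an aromatic carbon gives a number 25 percentage points higher from compound 1 to compound 4 (beyond the scatter) and is the first direct reading of that change.

No evidence on the cause of these steps is at hand. Still open, on these data alone, are how a longer chain or a cyclohexyl group on the saturated chain carbon would read, and how an amine or a carboxylic acid would compare with nitro on the aromatic carbon.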